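The source may hold more compounds than are shown below. What is called first, only, known or untested is meant among the compounds shown, and "the series" means these compounds.

Compound 1 `C#Cc1cccc(Nc2ncnn3ccc(CN4CCC(N)CC4)c23)c1` and compound 2 `CC(C)Nc1ncnn2ccc(CN3CCC(N)CC3)c12` share one core. In a functional assay on A2780 cells (Homo sapiens) for antiproliferative activity (on this read-out lower numbers stand for stronger inhibition and higher numbers for weaker inhibition), compound 1 gives 2300 nM, while compound 2 has the entry "not determined" (no result reported), so compound 2 has no place on this scale and offers no number to start from. Compound 3 `Cc1ccccc1Nc1ncnn2ccc(CN3CCC(N)CC3)c12` differs from it as follows: 2-methylphenyl in place of isopropyl on a nitrogen on an aromatic ring. This puts 2-methylphenyl in place of isopropyl on a nitrogen on an aromatic ring. Like compound 1 at 2300 nM, compound 3 has a six-membered aromatic ring of carbon only on that nitrogen, so no step beyond the scatter from that value is expected in this assay. The expected value for compound 3 is 2000 nM, with an estimated range of 600 nM to 7000 nM.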

Compound 3, half-maximal inhibitory concentration: > 5000 nM
Compound 3 gave a limit, no number; the forecaster's own chance of this, stated with the estimate: 15%; middle value at least 2.5-fold (0.39 log units) away from the limit.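

On this nitrogen, having a six-membered aromatic ring of carbon only does not by itself hold the activity: in this assay, replacing 3-ethynylphenyl with 2-methylphenyl gives an at least 2.1-fold higher number from compound 1 to compound 3 (0.33 log units; beyond the scatter). So the groups on that ring, or where they sit, matter at this position. The result for compound 3 is a limit and not a number: the limit of > 5000 nM in this assay, at which 1 of the 3 values shown sits.

The step from compound 2 cannot be read, as compound 2 has no result. On these data alone, how a plain phenyl, or a phenyl carrying an amine, would behave on this nitrogen stays open.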